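The source may hold more compounds than are shown below. What is called first, only, known or untested is meant among the compounds shown, and "the series" means these compounds.

Measured so far in a physicochemical assay for solubility; on this read-out higher numbers stand for higher solubility and lower numbers for lower solubility:
- compound 1 `O=C(O)c1ccc(C(=O)/C(=C\c2ccc(F)c([N+](=O)[O-])c2)SCc2ccccc2)cc1`: < 1000 ug/mL (a limit)
- compound 2 `O=C(O)c1ccc(C(=O)/C(=C\c2ccc(F)c([N+](=O)[O-])c2)SCc2ccc(Cl)cc2)cc1`: < 1000 ug/mL (a limit)

Compound 2 therefore stands only at a limit, without a number: the limit of < 1000 ug/mL in this assay, at which 2 of the 2 values shown sit. Compound 3 `O=C(O)c1ccc(C(=O)/C(=C\c2ccc(F)c([N+](=O)[O-])c2)SCc2ccccc2Cl)cc1` differs from it by 2-chlorophenyl in place of 4-chlorophenyl on a saturated chain carbon bound to a sulfur, with 4-chlorobenzyl replaced by 2-chlorobenzyl. Within the data shown here, the one measured step, a step that the two limits leave unreadable from compound 1 to compound 2, offers no size to carry over. No shift beyond the scatter is expected in this assay, so the expected change is a step that the limit leaves unreadable from compound 2 to compound 3. For compound 3 the estimate is 300 ug/mL, with an expected range of 50 ug/mL to 1000 ug/mL.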

Compound 3, solubility: < 1000 ug/mL
Compound 3: only a limit was reported (the forecaster's own chance of this, stated with the estimate: 80%); the middle value is on the limit's open side.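

No step can be read among compound 1, compound 2 and compound 3 in this assay because each is reported only as a limit: the limit of < 1000 ug/mL in this assay, at which 3 of the 3 values shown sit. The compounds shown leave open how soluble each actually is, and whether 2-chlorobenzyl and 4-chlorobenzyl differ at all.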